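The source may hold more compounds than are shown below. What is called first, only, known or untested is meant among the compounds shown, and "the series" means these compounds.

Measured so far:
- compound 2, `O=S(=O)(NCCCNCc1ccccc1)c1cc(C(F)(F)F)cc(C(F)(F)F)c1`: 16000 nM
- compound 1, `O=S(=O)(NCCCNCc1ccc(C(F)(F)F)cc1)c1cc(C(F)(F)F)cc(C(F)(F)F)c1`: 3200 nM

In a functional assay on PANC-1 cells (Homo sapiens) for inhibition, read by MTT assay, with a stated time of 72 h (a higher number here means a weaker inhibitor of growth, a lower number a stronger inhibitor of growth), compound 2 gives the higher of the two numbers shown, its only neighbour being compound 1, which gives 3200 nM. Among the measured compounds shown here, the single measured step, a 5.0-fold higher number from compound 1 to compound 2 (0.70 log units; beyond the scatter), concerns a trifluoromethyl on the benzyl ring, and it shows that taking a group off that ring made the number rise. Compound 3, `COc1ccccc1CNCCCNS(=O)(=O)c1cc(C(F)(F)F)cc(C(F)(F)F)c1`, differs from compound 2 by methoxy in place of hydrogen on an aromatic carbon: a methoxy in place of hydrogen, on an aromatic carbon of the benzyl ring, ortho to a large group. For the measured compounds named here, no measured step adds a methoxy, so the step from compound 1 to compound 2 bears on it only loosely, as a sign that this ring tolerates substituents without losing strength. A small drop in the number is therefore expected for compound 3, estimated as a 1.8-fold lower number from compound 2 to compound 3 (0.25 log units; within the scatter), giving 9000 nM with a range from 3000 nM to 27000 nM.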

Compound 3, concentration for 50% growth inhibition: 12000 nM
Compound 3: the middle estimate sits 1.3-fold (0.12 log units) below what was measured; the measured number falls inside the stated range.
By their numbers in this assay, from the lowest: compound 1; then compounds 3 and 2 (each within the scatter of the next).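

In this assay, adding the methoxy gives a 1.3-fold lower number from compound 2 to compound 3 (0.12 log units; within the scatter) and so, unlike the trifluoromethyl, it brings no change that stands clear of the scatter. Replacing 4-(trifluoromethyl)phenyl with 2-methoxyphenyl gives a 3.8-fold higher number from compound 1 to compound 3 (0.57 log units; beyond the scatter) and shows that a substituent on this ring does not by itself bring the number down to that of compound 1. No measurement here bears on why these two groups differ. That last step changes both the group and its place on the ring, so the contribution of each remains unresolved. Also open, from the compounds shown here alone, is how a nitrile, a chlorine atom or a carboxylic acid on this ring would compare, and what a longer chain between the two nitrogens would do.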